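A Shorter Unsaturated Chain on a Shared Core

The source may hold more compounds than are shown below. What is called first, only, known or untested is meant among the compounds shown, and "the series" means these compounds.

In a functional assay on HeLa cells (Homo sapiens) for inhibition, read by MTT assay, with a stated time of 48 h (on this read-out lower numbers stand for stronger inhibition and higher numbers for weaker inhibition), compound 1 `O=C(CCCCOc1no[n+]([O-])c1S(=O)(=O)c1ccccc1)NO` gives 3650 nM and compound 2 `O=C(CCCCCCCOc1no[n+]([O-])c1S(=O)(=O)c1ccccc1)NO` gives 5030 nM, two values within the usual scatter of each other. Compound 3 `O=C(/C=C/COc1no[n+]([O-])c1S(=O)(=O)c1ccccc1)NO` keeps the core of compound 1 but carries 2-(hydroxycarbamoyl)ethenyl in place of 3-(hydroxycarbamoyl)propyl on a saturated chain carbon bound to an oxygen on an aromatic ring. Among the compounds with values here, the only measured step, a 1.4-fold higher number from compound 1 to compound 2 (0.14 log units; within the scatter), alters chain length and stays within the scatter, and no measured step tests this unsaturated group, so the guidance is limited. The expected step, a 1.1-fold higher number from compound 1 to compound 3 (0.04 log units; within the scatter), is no larger than the scatter. Compound 3 is estimated at 4000 nM, with an expected range of 1500 nM to 10500 nM.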

Compound 3, half-maximal inhibitory concentration: 8740 nM
Compound 3: middle estimate off by 2.2-fold (0.34 log units), on the low side; low and high end bracket the measured number.
By their numbers in this assay, from the lowest: compounds 1, 2 and 3 (each within the scatter of the next, the first and the last beyond it).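

In this assay, within the data shown here, putting 2-(hydroxycarbamoyl)ethenyl in place of 3-(hydroxycarbamoyl)propyl gives a 2.4-fold higher number from compound 1 to compound 3 (0.38 log units; beyond the scatter) and so provides the first step here that lies beyond the scatter, though only a modest one. This shows that the number can shift with a change to the chain at this position. Nothing available explains the shift.

Going by these compounds, the new group differs from the old in both its double bond and its size, so the share of each remains open. Also open, on these data alone, is how a saturated chain of the same length, or a carboxylic acid in place of the hydroxycarbamoyl end, would read.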